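This account rests on a few compounds, and the source may have more. Where it says the series, first, only, none or still open, it means among the compounds named here.

Measured compounds in an ADME assay on HeLa Rh cells (Homo sapiens) for cytotoxicity, read by microscopy; a lower number here means that less compound is tolerated, a higher number that more compound is tolerated:
- compound 1 `COc1cc(CC(O)c2ccc(-c3ccc([N+](=O)[O-])cc3)cc2)c([N+](=O)[O-])cc1OC` gives 21000 nM
- compound 2 `COc1cc(CC(O)c2ccc(-c3cccc(Cl)c3)cc2)c([N+](=O)[O-])cc1OC` gives 5900 nM
- compound 3 `COc1cc(CC(O)c2ccc(-c3ccccc3F)cc2)c([N+](=O)[O-])cc1OC` gives 5000 nM

Compound 1 stands highest of the three numbers in this assay. For the measured compounds named here, the gap to compound 2 is a 3.6-fold lower number from compound 1 to compound 2 (0.55 log units; beyond the scatter) and the gap to compound 3 is a 4.2-fold lower number from compound 1 to compound 3 (0.62 log units; beyond the scatter); both are beyond the scatter, so compound 1 is the one that tolerates most compound. Between compounds 2 and 3 the step is a 1.2-fold lower number from compound 2 to compound 3 (0.07 log units; within the scatter), within the scatter, so nothing can be read into their order.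

Compound 4 `COc1cc(CC(O)c2ccc(-c3ccccc3[N+](=O)[O-])cc2)c([N+](=O)[O-])cc1OC` is not yet measured. Against compound 1 the change is 2-nitrophenyl in place of 4-nitrophenyl on an aromatic carbon.

The two measured steps that start from compound 1 both replace the 4-nitrophenyl group and both give modestly lower numbers. Neither of them keeps the nitro group on the entering ring, so they bear on the step to compound 4 only loosely. A modest drop in this assay is the more likely outcome, but a number near that of compound 1 cannot be ruled out. For compound 4 the expected step is a 1.8-fold lower number from compound 1 to compound 4 (0.24 log units; within the scatter). Compound 4 is therefore estimated at 12000 nM, with a range from 5500 nM to 26000 nM.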

Compound 4, half-maximal cytotoxic concentration: 9500 nM
The estimate for compound 4 lay 1.3-fold (0.10 log units) above the measured number, within the range that was stated.
By their numbers in this assay, from the lowest: compounds 3, 2 and 4 (each within the scatter of the next); then compound 1.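

In this assay, keeping the nitro group on the entering ring does not keep the number of compound 1: with the same atoms and only 2-nitrophenyl in place of 4-nitrophenyl, the result is a 2.2-fold lower number from compound 1 to compound 4 (0.34 log units; beyond the scatter) and so the site of the nitro group on that ring counts in this read-out, not only its presence. Compound 4 also does not separate from the halogen-bearing compounds, with a 1.9-fold higher number from compound 3 to compound 4 (0.28 log units; within the scatter) and a 1.6-fold higher number from compound 2 to compound 4 (0.21 log units; within the scatter) as the two steps, so of the four compounds only compound 1, the 4-nitrophenyl compound, stands apart from all the others. Nothing available gives a reason for this step.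

The compounds shown leave open whether the number of compound 1 belongs to the nitro group itself or could be matched by another group at that place, as an amine or a carboxylic acid on the same phenyl ring would test. They also leave open whether larger differences appear among compounds with the nitro group at its 2-position, such as with a methoxy or a second nitro group added to that ring.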